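The source may report more compounds than this note shows. Statements on the series, on what has been measured and on what is new or still open speak of the compounds shown alone.

Among the compounds with values here, in a functional assay on HeLa cells (Homo sapiens) for inhibition, with a stated time of 72 h (on this read-out lower numbers stand for stronger inhibition and higher numbers for weaker inhibition), compound 1 (`NC1CCC(Nc2nc(NCc3ccc(-c4ccccc4)cc3)c3ncn(C4CCCC4)c3n2)CC1`) gives 240 nM and holds the higher of the two numbers measured so far on this core, while compound 2 (`NC1CCC(Nc2nc(NCc3ccc(-c4ccco4)cc3)c3ncn(C4CCCC4)c3n2)CC1`) gives 71 nM in the same test. Within the data shown here, only one measured step bears on the next change. It replaces the phenyl with furan-2-yl, and it is modest but beyond the scatter (a 3.4-fold lower number from compound 1 to compound 2 (0.53 log units; beyond the scatter)).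

Compound 3 (`NC1CCC(Nc2nc(NCc3ccc(-n4cccn4)cc3)c3ncn(C4CCCC4)c3n2)CC1`) has not yet been measured. It carries 1H-pyrazol-1-yl in place of phenyl on an aromatic carbon, so, as in compound 2, a five-membered aromatic ring stands where the phenyl stood. One step is thin evidence, and the data do not show how far a result for furan-2-yl carries over to 1H-pyrazol-1-yl. In this assay a somewhat smaller move in the same direction is therefore expected (a 2.4-fold lower number from compound 1 to compound 3 (0.38 log units; beyond the scatter)), and a result within the scatter of compound 1 would not be surprising. The estimated value for compound 3 is 100 nM within an expected range of 35 nM to 290 nM (an estimate, not a measurement).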

Compound 3, half-maximal inhibitory concentration: 170 nM
Compound 3: middle estimate off by 1.7-fold (0.23 log units), on the low side, within the range that was stated.
By their numbers in this assay, from the lowest: compound 2; then compounds 3 and 1 (each within the scatter of the next).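

In this assay, a five-membered aromatic ring at this place does not by itself bring the gain seen with furan-2-yl: exchanging phenyl for 1H-pyrazol-1-yl gives a 1.4-fold lower number from compound 1 to compound 3 (0.15 log units; within the scatter) and so leaves compound 3 not distinguishable from compound 1. The two five-membered rings are not interchangeable on an aromatic carbon para to a large group, as exchanging furan-2-yl for 1H-pyrazol-1-yl gives a 2.4-fold higher number from compound 2 to compound 3 (0.38 log units; beyond the scatter) and compound 2 alone stands clear of the other two compounds, with the lowest number of the three. No measurement available here accounts for this difference between the two rings.

As far as these compounds go, it remains open whether a thiophen-2-yl or a 1H-pyrazol-4-yl ring at this place would give a number like that of compound 2 or like that of compound 3. Also open, from the compounds shown here alone, is how the number would respond if an amine or a carboxylic acid stood on the outer ring, or if a simple methoxy group replaced that ring altogether.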